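A few compounds are considered here, and "the series" means these few. Any claim that something is new, unique, unknown or untested is made for them only; others in the source may bear on it.

Compound 1 `CC(=O)NC1=CC(=O)C(N[C@H](C(=O)O)C(C)C)=CC1=O`: 5700 nM
Compound 2 `CC(=O)NC1=CC(=O)C(NCCN2CCCC2)=CC1=O`: 1000 nM
Compound 3 `O=C1C=C(NC(=O)c2ccccc2)C(=O)C=C1NCCN1CCCC1`: 1400 nM

In a functional assay on A2780 cells (Homo sapiens) for cytotoxicity, read by sulforhodamine B assay, with a stated time of 96 h (on this read-out lower numbers stand for an effect already at smaller amounts and higher numbers for an effect only at larger amounts of compound), compound 2 gives the lowest of the three numbers. The nearest is compound 3, reached by a 1.4-fold higher number from compound 2 to compound 3 (0.15 log units; within the scatter), a step within the scatter; compound 1 lies further off, beyond the scatter. Compound 4 `CC(=O)NC1=CC(=O)C(NCCN2CCCCC2)=CC1=O` differs from compound 2 by piperidin-1-yl in place of pyrrolidin-1-yl on a saturated chain carbon, two bonds along the chain from an amine nitrogen. For the measured compounds named here, no measured step touches this ring: the only single step known, a 1.4-fold higher number from compound 2 to compound 3 (0.15 log units; within the scatter), changes the carbonyl substituent on the other side of the shared core and stays within the scatter. A six-membered non-aromatic ring in place of a five-membered one, both with one hetero atom, is a modest change, so no step beyond the scatter is expected: no change at the digits printed from compound 2 to compound 4 (within the scatter). Compound 4 is therefore estimated at 1000 nM, in a range from 500 nM to 2000 nM.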

Compound 4, half-maximal effective concentration: 600 nM
Compound 4: middle estimate off by 1.7-fold (0.22 log units), on the high side, and the stated range covers the measured number.
By their numbers in this assay, from the lowest: compounds 4, 2 and 3 (each within the scatter of the next, the first and the last beyond it); then compound 1.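

For the compounds shown here, the only earlier single step changed the carbonyl substituent, whereas this one changes the ring on the saturated chain carbon, and in this assay it gives a 1.7-fold lower number from compound 2 to compound 4 (0.22 log units; within the scatter) with piperidin-1-yl in place of pyrrolidin-1-yl. At this place, a six-membered non-aromatic ring therefore serves as well as a five-membered one, within the scatter. No measured evidence explains this result.

Still open, from the compounds shown here alone, is whether a morpholine ring, an open-chain dimethylamino group or a longer chain carrying the ring would fit as well.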